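The source may report more compounds than this note shows. Statements on the series, on what has been measured and on what is new or still open speak of the compounds shown alone.

Measured so far in a functional assay on GC3/MTK- cells (Homo sapiens) for inhibition; on this read-out lower numbers stand for stronger inhibition and higher numbers for weaker inhibition:
- compound 1 `C#CCN(Cc1ccc2nc(C)nc(O)c2c1)c1cccc(C(F)(F)F)c1` gives > 4300 nM, a limit
- compound 2 `C#CCN(Cc1ccc2nc(C)nc(O)c2c1)c1cccc(I)c1` gives > 5300 nM, a limit
- compound 3 `C#CCN(Cc1ccc2nc(C)nc(O)c2c1)c1ccc(C(=O)c2ccccc2)cc1` gives 6200 nM

Going by the values given here, compound 3, at 6200 nM, holds the only number among the three. The values of compound 1 and compound 2 are limits.

The change under study leads to compound 4 `C#CCN(Cc1ccc2nc(C)nc(O)c2c1)c1ccc(S(=O)(=O)N2CCN(C)CC2)cc1` and is (4-methylpiperazin-1-yl)sulfonyl in place of benzoyl on an aromatic carbon. Among the compounds with values here, the only measured step is a step that the two limits leave unreadable from compound 1 to compound 2. That step is iodo in place of trifluoromethyl, a different exchange, and its size cannot be read, so it gives no magnitude or direction to carry over. Within the data shown here, no measured pair tests the exchange of benzoyl for (4-methylpiperazin-1-yl)sulfonyl. The expectation in this assay therefore starts from compound 3 at 6200 nM, with no shift expected beyond the scatter and a wide margin on either side.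

The expected step is a 1.3-fold higher number from compound 3 to compound 4 (0.11 log units; within the scatter).

Compound 4 is estimated at 8000 nM, with an expected range from 2500 nM to 30000 nM.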

Compound 4, half-maximal inhibitory concentration: > 10000 nM
Compound 4 ended at the assay's limit; the forecaster's own chance of this, stated with the estimate: 40%; at least 1.2-fold (0.09 log units) between middle value and limit.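

In this assay compound 4 gives > 10000 nM, a limit. The exchange of benzoyl for (4-methylpiperazin-1-yl)sulfonyl, on an aromatic carbon para to a large group, gives an at least 1.6-fold higher number from compound 3 to compound 4 (0.20 log units; that floor lies within the scatter), so this change shows no sign of stronger inhibition, and the only floor it offers does not clear the scatter. The true size of the step cannot be read because the value of compound 4 is a limit: the limit of > 10000 nM in this assay, at which 1 of the 4 values shown sits.

Open, on these data alone, is whether a simple methylsulfonyl group at this place, without the piperazine ring, would behave like the (4-methylpiperazin-1-yl)sulfonyl group or like benzoyl. Also open, as far as these compounds go, is whether a carboxylic acid or a primary amine at the same aromatic carbon would give a number clearly lower than that of compound 3.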